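Pyrrolidine side chain: cyanomethyl to hydroxy at compound 4

A few compounds are considered here, and "the series" means these few. Any claim that something is new, unique, unknown or untested is made for them only; others in the source may bear on it.

Measured so far in a functional assay on cells for antagonist activity at C-C chemokine receptor type 4 (Homo sapiens), read by fluorescence and calcium flux, with stated times of 2.5 s and 45 s; a lower number here means a stronger inhibitor, a higher number a weaker inhibitor:
compound 1, `Cc1nn([C@H](C)c2ccc(Cl)cc2Cl)c2nc(N3CC[C@H](N4CCC[C@H]4CCS(C)(=O)=O)[C@H](C)C3)cnc12`, 104 nM
compound 2, `Cc1nn([C@H](C)c2ccc(Cl)cc2Cl)c2nc(N3CC[C@H](N4CCC[C@H]4CCC#N)[C@H](C)C3)cnc12`, 41 nM
compound 3, `C[C@@H](Nc1cncc(C2=CCN(C(=O)[C@H]3CCCCN3)CC2)n1)c1ccc(Cl)cc1Cl`, 54 nM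

Compound 2 gives the lowest of the three numbers in this assay. Its gap to compound 3, which has a different core, lies within the scatter, so the two are not distinguished; its gap to compound 1 lies beyond the scatter.

Compound 4, `Cc1nn([C@H](C)c2ccc(Cl)cc2Cl)c2nc(N3CC[C@H](N4CCC[C@H]4CO)[C@H](C)C3)cnc12`, shares the core of compound 2 and differs only in the pyrrolidine side chain: hydroxy in place of cyanomethyl on a saturated chain carbon bound to a saturated ring carbon. Among the compounds with values here, one measured step touches this same chain: a 2.5-fold lower number from compound 1 to compound 2 (0.40 log units; beyond the scatter). That step exchanged one acceptor-bearing group for another further out along the chain and moved the number only modestly. Within the data shown here, no measured pair exchanges a group for a hydroxy, so the direction of the present change is unread. The expectation is therefore a step of about the same modest size as from compound 1 to compound 2, or none beyond the scatter, with a slightly higher number as the more likely outcome.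

Compound 4 is estimated at 65 nM (range 25 nM to 170 nM), which means an expected step of a 1.6-fold higher number from compound 2 to compound 4 (0.20 log units; within the scatter).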

Compound 4, half-maximal inhibitory concentration: 32 nM
Beside the measured number, compound 4's estimate is 2.0-fold (0.31 log units) above it; measured number inside the range.
By their numbers in this assay, from the lowest: compounds 4, 2, 3 and 1 (each within the scatter of the next, the first and the last beyond it).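

In this assay, hydroxy in place of cyanomethyl on a saturated chain carbon bound to a saturated ring carbon gives a 1.3-fold lower number from compound 2 to compound 4 (0.11 log units; within the scatter) and so does not separate the two groups, even though the change leaves 1 heavy atom where there were 3 and brings 1 hydrogen-bond donor where there were 0. Hydroxy in place of (methylsulfonyl)methyl at the same place gives a 3.3-fold lower number from compound 1 to compound 4 (0.51 log units; beyond the scatter) and so, among the three side chains on this core, only the sulfone-bearing chain of compound 1 stands apart. Nothing measured here bears on why these numbers fall as they do.

Open, as far as these compounds go, is how far this place tolerates other groups, such as a methoxy, a primary amine or a carboxylic acid. Also open, from the compounds shown here alone, is whether a longer chain ending in hydroxy reads like compound 4.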